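Replacing the Pyrazine Tip with a Cyanopyridine

The source may report more compounds than this note shows. Statements on the series, on what has been measured and on what is new or still open speak of the compounds shown alone.

Compound 1 `CCC(C)(C)Cc1c[nH]c(CCc2ccc(-c3ccncc3)cc2)n1`: 101 nM
Compound 2 `CCC(C)(C)Cc1c[nH]c(CCc2ccc(-n3ccnn3)cc2)n1`: 390 nM
Compound 3 `CCC(C)(C)Cc1c[nH]c(CCc2ccc(-c3cnccn3)cc2)n1`: 51 nM

All three share one core and differ only in the ring attached to the aromatic carbon, as measured in an in vitro assay on CHO cells for displacement of a labelled ligand from Bombesin receptor subtype-3 (Homo sapiens), read by scintillation counting, with a stated time of 2 h; a higher number here means a weaker inhibitor, a lower number a stronger inhibitor. Compound 3 gives the lowest number of the three, yet its gap to compound 1, a 2.0-fold lower number from compound 1 to compound 3 (0.30 log units; within the scatter), lies within the scatter, so no order between those two can be claimed; only compound 2 stands clearly apart, with a 7.6-fold lower number from compound 2 to compound 3 (0.88 log units; beyond the scatter). Compound 4 `CCC(C)(C)Cc1c[nH]c(CCc2ccc(-c3cccc(C#N)n3)cc2)n1` carries 6-cyanopyridin-2-yl in place of pyrazin-2-yl on an aromatic carbon. The two steps ending at compound 3 show that exchanging one six-membered ring for another changed little, while the five-membered ring in compound 2 cost modestly. A six-membered ring stays, so little movement beyond the scatter is expected in this assay. Compound 4 is therefore estimated at 80 nM, with a range of 25 nM to 250 nM. That estimate means an expected step of a 1.6-fold higher number from compound 3 to compound 4 (0.20 log units; within the scatter).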

Compound 4, half-maximal inhibitory concentration: 140 nM
Compound 4: the middle estimate sits 1.8-fold (0.24 log units) below what was measured; the range from low to high includes it.
By their numbers in this assay, from the lowest: compounds 3, 1 and 4 (each within the scatter of the next, the first and the last beyond it); then compound 2.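

Among the exchanges of one six-membered ring for another, only 6-cyanopyridin-2-yl in place of pyrazin-2-yl moves beyond the scatter, with a 2.7-fold higher number from compound 3 to compound 4 (0.44 log units; beyond the scatter). Yet 6-cyanopyridin-2-yl cannot be separated from pyridin-4-yl, with a 1.4-fold higher number from compound 1 to compound 4 (0.14 log units; within the scatter), and it still differs clearly from the five-membered ring, with a 2.8-fold lower number from compound 2 to compound 4 (0.44 log units; beyond the scatter). Nothing available explains these differences. On these data alone, the nitrile and the change in ring nitrogens arrive together, so their separate contributions remain open. A plain pyridin-2-yl, or one carrying an amine in place of the nitrile, would help separate them.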